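Moving the Fluoromethyl Group Along a Short Side Chain

The source may hold more compounds than are shown below. What is called first, only, known or untested is meant among the compounds shown, and "the series" means these compounds.

Compound 1, `COc1cc(C(c2ccc(O)c(OC)c2)[C@@H](C)[C@@H](C)CF)ccc1O`, gives 38000 nM in a functional assay on HL-60 cells (Homo sapiens) for cytotoxicity, read by WST assay, with a stated time of 48 h; on this read-out lower numbers stand for stronger inhibition and higher numbers for weaker inhibition.
Compound 2, `COC[C@@H](C(C)C)C(c1ccc(O)c(OC)c1)c1ccc(O)c(OC)c1`, gives 54000 nM.
Compound 3, `COc1cc(C(c2ccc(O)c(OC)c2)[C@@H](C)[C@H](C)CF)ccc1O`, gives 32000 nM.

These three compounds share one core and differ only in the short saturated chain attached to the carbon that carries the two aromatic rings. Within the data shown here, compound 1 sits among the other two rather than apart from them: a 1.4-fold higher number from compound 1 to compound 2 (0.15 log units; within the scatter) and a 1.2-fold lower number from compound 1 to compound 3 (0.07 log units; within the scatter), so no compound of the three is set off from the rest.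

Compound 4, `COc1cc(C(c2ccc(O)c(OC)c2)[C@@H](CF)C(C)C)ccc1O`, has not yet been measured. It keeps every atom of compound 1 and only joins them differently: 1-(fluoromethyl)-2-methylpropyl in place of 2-(fluoromethyl)-1-methylpropyl on a saturated chain carbon bound to two aromatic carbons. The measured steps that bear on such a rearrangement of the chain are the exchanges of one chain for another, a 1.4-fold higher number from compound 1 to compound 2 (0.15 log units; within the scatter) and a 1.7-fold lower number from compound 2 to compound 3 (0.23 log units; within the scatter), and the change of drawn configuration alone, a 1.2-fold lower number from compound 1 to compound 3 (0.07 log units; within the scatter). All three stay within the scatter, and none points in a consistent direction. For compound 4 in this assay the expectation is therefore no step beyond the scatter in either direction.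

Compound 4 is expected to give 40000 nM, with a range from 20000 nM to 80000 nM. That estimate means a 1.1-fold higher number from compound 1 to compound 4 (0.02 log units; within the scatter), a step expected to stay within the scatter.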

Compound 4, half-maximal inhibitory concentration: 39000 nM
Beside the measured number, compound 4's estimate is 1.0-fold (0.01 log units) above it, within the range that was stated.
By their numbers in this assay, from the lowest: compounds 3, 1, 4 and 2 (each within the scatter of the next).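

In this assay, putting 1-(fluoromethyl)-2-methylpropyl in place of 2-(fluoromethyl)-1-methylpropyl gives a 1.0-fold higher number from compound 1 to compound 4 (0.01 log units; within the scatter) and a 1.2-fold higher number from compound 3 to compound 4 (0.09 log units; within the scatter), so a rearrangement that keeps every atom of the chain and leaves one defined stereocentre instead of two stays within the scatter in both readings. These two readings can be taken as the same change of chain seen from two drawn configurations: the fact that compounds 1 and 3 differ only in the configuration as drawn. Compound 4 also adds the first exchange shown on an unchanged chain skeleton, fluoro in place of methoxy on a saturated chain carbon, three bonds along the chain from two aromatic carbons, and this gives a 1.4-fold lower number from compound 2 to compound 4 (0.14 log units; within the scatter).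

All four compounds lie within the scatter of one another in this single cell assay, so the series gives no sign of how a group of a different kind would behave on this chain. Among these compounds, an amine or a carboxylic acid in place of the fluoro, a longer chain on the carbon bound to the two aromatic carbons, and the opposite drawn configuration at the one stereocentre of compound 4 all remain open.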